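Cyclohexylmethyl ether of compound 3: expected step

This account rests on a few compounds, and the source may have more. Where it says the series, first, only, none or still open, it means among the compounds named here.

In a functional assay (Left cardiac atrium, Cavia porcellus), with a stated time of 30 min (on this read-out lower numbers stand for an effect already at smaller amounts and higher numbers for an effect only at larger amounts of compound), compound 1 (`CC1=CSC(O)(c2ccccc2)c2noc(=O)n21`) gives 230 nM, compound 2 (`CC1=CSC(OC(C)C)(c2ccccc2)c2noc(=O)n21`) gives 1190 nM and compound 3 (`COc1cccc(C2(O)SC=C(C)n3c2noc3=O)c1`) gives 490 nM, which places compound 3 between the other two. Compound 4 (`COc1cccc(C2(OCC3CCCCC3)SC=C(C)n3c2noc3=O)c1`) differs from compound 3 by cyclohexylmethyl in place of hydrogen on an oxygen on a saturated carbon, with cyclohexylmethyl in place of hydrogen on an oxygen on a saturated carbon. Within the data shown here, the nearest precedent is isopropyl in place of hydrogen at that kind of place, a 5.2-fold higher number from compound 1 to compound 2 (0.71 log units; beyond the scatter). The methoxy step, a 2.1-fold higher number from compound 1 to compound 3 (0.33 log units; beyond the scatter), is already contained in compound 3 and bears on the change only as background. Among the measured compounds shown here, no measured compound carries cyclohexylmethyl, so the size remains uncertain. A move to a higher number of similar size is expected, a 4.5-fold higher number from compound 3 to compound 4 (0.65 log units; beyond the scatter). Compound 4 is estimated at 2200 nM, with an expected range of 800 nM to 6500 nM.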

Compound 4, half-maximal effective concentration: 650 nM
For compound 4 the middle estimate is 3.4-fold (0.53 log units) above the measured one, and the stated range ends above it.
By their numbers in this assay, from the lowest: compound 1; then compounds 3, 4 and 2 (each within the scatter of the next, the first and the last beyond it).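

Ether formation at this oxygen need not cost much in this assay: cyclohexylmethyl replaces hydrogen with a step within the scatter (a 1.3-fold higher number from compound 3 to compound 4 (0.12 log units; within the scatter)). The isopropyl step (a 5.2-fold higher number from compound 1 to compound 2 (0.71 log units; beyond the scatter)) lay beyond the scatter, but it was read on the compound without methoxy, so the size of this change depends on the group entering, the aromatic methoxy, or both. No measured evidence on any property accounts for this result. Open, as far as these compounds go, is whether cyclohexylmethyl on compound 1 gives a similarly small step, and how a carboxylic acid or an amine on this oxygen would read.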